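This account rests on a few compounds, and the source may have more. Where it says the series, first, only, none or still open, it means among the compounds named here.

Measured compounds:
compound 1, `COc1cccc(CNCCCNc2ccnc3cc(Oc4ccccc4)ccc23)c1O`, gives 6800 nM
compound 2, `c1ccc(CCc2ccc3c(NCCCNCc4ccco4)ccnc3c2)cc1`, gives 16000 nM

Both numbers come from an ADME assay on HepG2 cells (Homo sapiens) for cytotoxicity, read by luminescence, CellTiter-Glo and ATP content, with a stated time of 72 h; a lower number here means that less compound is needed, a higher number that more compound is needed for the effect. Compound 1 holds the lower of the two values; compound 2 sits higher, and that gap lies beyond the usual scatter. Compound 3, `COc1cccc(Oc2ccc3c(NCCCNCc4cccc(OC)c4O)ccnc3c2)c1`, is not yet measured. It differs from compound 1 by methoxy in place of hydrogen on an aromatic carbon. Among the compounds with values here, no step of this kind between measured compounds is available, so the direction is open; a step within the scatter, in either direction, is expected. For compound 3 the expected value in this assay is 7000 nM, within 3000 nM to 16000 nM. This expectation corresponds to a step of a 1.0-fold higher number from compound 1 to compound 3 (0.01 log units; within the scatter).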

Compound 3, half-maximal effective concentration: 5300 nM
Beside the measured number, compound 3's estimate is 1.3-fold (0.12 log units) above it; the measured number falls inside the stated range.
By their numbers in this assay, from the lowest: compounds 3 and 1 (each within the scatter of the next); then compound 2.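

Going from phenoxy to 3-methoxyphenoxy gives the first step read at this position: in this assay, a 1.3-fold lower number from compound 1 to compound 3 (0.11 log units; within the scatter). On this core, then, methoxy in place of hydrogen on this aromatic carbon leaves the number within the scatter of compound 1. No evidence is available to account for the size of this step.

From the compounds shown here alone, it remains open whether an amine or a carboxylic acid on the same aromatic carbon would also stay within the scatter. Also open, going by these compounds, is whether methoxy on another carbon of this ring would give a step of similar size.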